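Series notes: swapping the aniline amide for a sulfonamide

This account rests on a few compounds, and the source may have more. Where it says the series, first, only, none or still open, it means among the compounds named here.

Compound 1 `CCCNc1nc(NCc2ccc(NC(=O)c3ccc(F)cc3)cc2)c2ccccc2n1` gives 1700 nM in a functional assay on HCT-116 cells (Homo sapiens) for inhibition, read by luminescence and resazurin assay, with a stated time of 3 days; on this read-out lower numbers stand for stronger inhibition and higher numbers for weaker inhibition.
Compound 2 `CN(C)c1nc(NCc2ccc(NC(=O)c3ccncc3)cc2)c2ccccc2n1` gives 15000 nM in this assay.
Compound 3 `CN1CCN(c2nc(NCc3ccc(NC(=O)c4ccncc4)cc3)c3ccccc3n2)CC1` reaches only the limit > 20000 nM in this assay.

Compound 2 holds the highest of the two numbers seen; the nearest is compound 1, with a lower number, beyond the scatter, and the third value is a limit (the limit of > 20000 nM in this assay, at which 1 of the 3 values shown sits). Among the compounds with values here, the one measured step, an at least 1.3-fold higher number from compound 2 to compound 3 (0.12 log units; that floor lies within the scatter), sits at the amine on the core and does not touch the aniline amide.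

Compound 4 `Cc1ccc(S(=O)(=O)Nc2ccc(CNc3nc(N(C)C)nc4ccccc34)cc2)cc1` differs from compound 2 by (4-methylphenyl)sulfonyl in place of (pyridin-4-yl)carbonyl on a nitrogen on an aromatic ring. Within the data shown here, no measured step bears on this change: compound 1 and compound 2 differ in two places and give no single step. The expectation therefore rests on compound 2 alone, with wide uncertainty, and a step of a 1.5-fold lower number from compound 2 to compound 4 (0.18 log units; within the scatter) is estimated. Compound 4 is expected at 10000 nM, within 3000 nM to 30000 nM, with a real chance that only a limit is returned.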

Compound 4, half-maximal inhibitory concentration: 11000 nM
Compound 4: the middle estimate sits 1.1-fold (0.04 log units) below what was measured; low and high end bracket the measured number.
By their numbers in this assay, from the lowest: compound 1; then compounds 4 and 2 (each within the scatter of the next). At a limit, above all of these: compound 3.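

In this assay, within the data shown here, (4-methylphenyl)sulfonyl in place of (pyridin-4-yl)carbonyl on a nitrogen on an aromatic ring gives a 1.4-fold lower number from compound 2 to compound 4 (0.13 log units; within the scatter) and so the first single-place reading at this nitrogen stays within the scatter. The earlier compounds shown here changed only the amine on the core, whereas here the carbonyl gives way to a sulfonyl and the ring with a hetero atom to a ring of carbon only, and the number does not move beyond the scatter. Nothing measured here gives a reason for this step.

Open, on these data alone, is whether the same exchange would stay as flat with the amine of compound 1 on the core. Also open, as far as these compounds go, is whether a methylsulfonyl group, or a carboxylic acid on the aromatic ring of the sulfonyl, would move the number beyond the scatter.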